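Replacing hydroxy with methoxymethyl on compound 2

The compounds below may be only part of what the source reports. "The series", "measured", "known", "first", "only" and "open" are said of these compounds alone.

Measured values in a physicochemical assay for solubility, using the shake flask method, in phosphate buffer, with a stated time of 24 h, at pH 6.8 (on this read-out higher numbers stand for higher solubility and lower numbers for lower solubility), are:
Compound 1 `COCCNC(=C\C(=O)/C=C/c1ccc(O)cc1)/C=C/c1ccc(O)cc1` gives 46100 nM
Compound 2 `O=C(/C=C(/C=C/c1ccc(O)cc1)NCCO)/C=C/c1ccc(O)cc1` gives 37900 nM

Among the compounds with values here, compound 2 stands level with compound 1, the only other measured compound. Within the data shown here, the single measured step is a 1.2-fold lower number from compound 1 to compound 2 (0.09 log units; within the scatter) and it is small. Compound 3 `COCCCNC(=C\C(=O)/C=C/c1ccc(O)cc1)/C=C/c1ccc(O)cc1` differs from compound 2 by methoxymethyl in place of hydroxy on a saturated chain carbon, two bonds along the chain from an amine nitrogen which reads as 2-hydroxyethyl to 3-methoxypropyl. Among the measured compounds shown here, that measured step is the only one bearing on this change, and no measured pair covers the whole of it. No step beyond the scatter is therefore expected in this assay and no direction can be named. The expected change is a 1.0-fold higher number from compound 2 to compound 3 (0.00 log units; within the scatter) on this estimate. For compound 3 the estimated value is 38000 nM with an expected range from 17000 nM to 80000 nM in this read-out.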

Compound 3, solubility: 14900 nM
Compound 3: the middle estimate sits 2.6-fold (0.41 log units) above what was measured, outside the stated range (below it).
By their numbers in this assay, from the lowest: compound 3; then compounds 2 and 1 (each within the scatter of the next).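

In this assay, this position on the amine side chain can move the number after all: the change to 3-methoxypropyl gave a step beyond the scatter (a 2.5-fold lower number from compound 2 to compound 3 (0.41 log units; beyond the scatter)). The same holds with methoxymethyl in place of methoxy (a 3.1-fold lower number from compound 1 to compound 3 (0.49 log units; beyond the scatter)), whereas hydrogen in place of methyl on the oxygen stayed within the scatter (a 1.2-fold lower number from compound 1 to compound 2 (0.09 log units; within the scatter)). Nothing available explains these steps. On these data alone, whether 3-hydroxypropyl would follow compound 3 or compound 2 remains open. So does the effect of a longer chain or of an amine at the chain end.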